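This account rests on a few compounds, and the source may have more. Where it says the series, first, only, none or still open, it means among the compounds named here.

Compound 1 `NC1=NC2(CCSCC2)N(OCCCOc2cccc(Cl)c2Cl)C(N)=N1` — 89.8%
Compound 2 `NC1=NC2(CCSCC2)N(OCCCOc2ccc(Cl)cc2)C(N)=N1` — "not determined" (no result reported)

For the measured compounds named here, compound 1 is the only member of this small set with a number. In an assay on isolated protein for inhibition of Dihydrofolate reductase (Homo sapiens), read by spectrophotometry, using NADPH, with stated times of 5 s and 6 min, tested at 50 uM (a lower number here means a weaker effect, a higher number a stronger effect of the compound at the concentration tested), compound 1 gives 89.8%. Going by the values given here, compound 2 shares the core of compound 1 and differs only in the substitution of its phenoxy ring, but in this assay compound 2 stands at "not determined" (no result reported), so there is no single number on which compound 2 stands, and no step between measured compounds can be drawn for it.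

Compound 3 `CC(C)(C)c1ccc(OCCCON2C(N)=NC(N)=NC23CCSCC3)cc1` is the next compound to be measured. It differs from compound 2 by tert-butyl in place of chloro on an aromatic carbon, the new group sitting on an aromatic carbon of the six-membered aromatic ring, para to a large group. Among the compounds with values here, with no value for compound 2 and no measured step to rest on, the size of the step in this assay from compound 2 to compound 3 cannot be anchored; a shift in either direction beyond the scatter is possible, and none beyond the scatter cannot be excluded. Compound 3 is expected to give about 70% in this assay, with a likely range from 30% to 95%.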

Compound 3, a percentage reported as inhibition, at one concentration (the size of the read-out at that concentration, not a potency): 86.6%
Compound 3: the middle estimate sits 16.6 percentage points below what was measured, within the range that was stated.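

For the compounds shown here, compound 2 has no reported result in this assay, so no step from it to compound 3 can be read. The compounds shown leave open whether tert-butyl in place of chloro on the aromatic ring changes inhibition of the enzyme at all. Nothing shown here offers an explanation for the value of compound 3.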